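The source may hold more compounds than are shown below. What is called first, only, known or untested is meant among the compounds shown, and "the series" means these compounds.

Measured in a functional assay on HeLa cells (Homo sapiens) for inhibition, read by sulforhodamine B assay; on this read-out lower numbers stand for stronger inhibition and higher numbers for weaker inhibition:
- Compound 1 `CCc1ccc(NC2=CC(=O)c3c(nc4n3[C@H]3OC[C@@H](O)[C@H]3OC4)C2=O)cc1`: 6510 nM
- Compound 2 `O=C1C=C(Nc2cccc(F)c2)C(=O)c2c1nc1n2[C@H]2OC[C@@H](O)[C@H]2OC1`: 6440 nM
- Compound 3 `COc1ccc(NC2=CC(=O)c3c(nc4n3[C@H]3OC[C@@H](O)[C@H]3OC4)C2=O)cc1`: > 8000 nM

Compound 2 gives 6440 nM and compound 1 gives 6510 nM, so the two stand within the usual scatter of each other. Compound 3 reads > 8000 nM, which is a limit of the assay and not a number.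

The next compound is compound 4 `Cc1ccc(NC2=CC(=O)c3nc4n(c3C2=O)[C@H]2OC[C@@H](O)[C@H]2OC4)cc1C`, which keeps the shared core of compound 2. It carries 3,4-dimethylphenyl in place of 3-fluorophenyl on an amine nitrogen.

No measurement covers this exact swap. The closest evidence is a single step with methoxy in place of ethyl on an aromatic carbon, an at least 1.2-fold higher number from compound 1 to compound 3 (0.08 log units; that floor lies within the scatter). Its floor lies within the scatter, so it gives no firm size for a change of this kind. With so little to go on, no shift beyond the scatter is expected in this assay, though a limit rather than a number remains possible. The expected change is a 1.1-fold lower number from compound 2 to compound 4 (0.03 log units; within the scatter), which would stay within the scatter. Compound 4 is estimated at 6000 nM, with an expected range of 3000 nM to 11000 nM.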

Compound 4, half-maximal inhibitory concentration: 2690 nM
The estimate for compound 4 lay 2.2-fold (0.35 log units) above the measured number; the whole stated range lies above it.
By their numbers in this assay, from the lowest: compound 4; then compounds 2 and 1 (each within the scatter of the next). At a limit, above all of these: compound 3.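

At the amine nitrogen of the shared core, the choice of aryl group can shift the result: in this assay, 3,4-dimethylphenyl in place of 3-fluorophenyl gives a 2.4-fold lower number from compound 2 to compound 4 (0.38 log units; beyond the scatter). This is the first step among these compounds that lies beyond the scatter, and it points to stronger inhibition, so this position is not indifferent to what it carries. The ring itself stays the same six-membered aromatic carbon ring, and the step replaces only what hangs on it, with the fluorine leaving and the methyl groups entering together, so a change in these ring substituents alone is enough to move the number.

Because the swap does two things at once, it cannot say whether losing the fluorine or gaining the methyl groups produces the step, and an unsubstituted phenyl or a ring carrying a single methyl would be needed to separate the two. How a ring bearing an amine or a carboxylic acid would behave also stays open, and the weak end of the scale is cut off for comparison: the limit of > 8000 nM in this assay, at which 1 of the 4 values shown sits.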